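The source may report more compounds than this note shows. Statements on the series, on what has been measured and on what is new or still open speak of the compounds shown alone.

Measured in a functional assay on A2780 cells (Homo sapiens) for antiproliferative activity; a lower number here means a stronger inhibitor, a higher number a weaker inhibitor:
- compound 1 `COc1cc(/C=C\Cc2cc(O)c3ccsc3c2)cc(OC)c1OC`: 70 nM
- compound 2 `COc1cc(/C=C\Cc2cc(O)c3ccoc3c2)cc(OC)c1OC`: 50 nM

For the measured compounds named here, compound 1 at 70 nM and compound 2 at 50 nM lie within the scatter of each other, so compound 1 stands level with the only other measured compound. The next compound is compound 3 `COc1cc(/C=C\Cc2cc(OP(=O)(O)O)c3ccsc3c2)cc(OC)c1OC`, which differs from compound 1 by a group of 4 heavy atoms (3 oxygen, 1 phosphorus; no ring) in place of a hydrogen atom, on an oxygen on an aromatic ring, with the new group on an oxygen on an aromatic ring. Going by the values given here, no measured pair shows this change, so the data give no direct guide to its size. In this assay, a step within the scatter or a modest move towards a weaker number is expected, with wide uncertainty in either direction. The estimated change is a 1.3-fold higher number from compound 1 to compound 3 (0.11 log units; within the scatter). For compound 3 the estimated value is 90 nM, with an expected range of 30 nM to 400 nM.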

Compound 3, half-maximal inhibitory concentration: 500 nM
For compound 3 the middle estimate is 5.6-fold (0.74 log units) below the measured one; the whole stated range lies below it.
By their numbers in this assay, from the lowest: compounds 2 and 1 (each within the scatter of the next); then compound 3.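

In this assay, for the compounds shown here, placing a group of 4 heavy atoms (3 oxygen, 1 phosphorus; no ring) in place of the hydrogen on this oxygen on an aromatic ring gives a 7.1-fold higher number from compound 1 to compound 3 (0.85 log units; beyond the scatter), the first step beyond the scatter. This oxygen is therefore not indifferent to change, although compound 3 still records a finite value of 500 nM. Nothing measured here bears on the reason for the weaker number.

As far as these compounds go, it remains open whether this step is specific to the phosphorus-containing group or would follow any replacement of that hydrogen, which a methyl ether or an acetyl ester on the same oxygen would help to separate. From the compounds shown here alone, it is also open whether the same group on compound 2 would give a step of similar size.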